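The source may hold more compounds than are shown below. What is called first, only, known or untested is meant among the compounds shown, and "the series" means these compounds.

Measured compounds:
Compound 1 `O=S(=O)(NCCCCNCc1ccc(Br)cc1)c1cc(C(F)(F)F)cc(C(F)(F)F)c1` — in a functional assay on A2780 cells (Homo sapiens) for inhibition, read by MTT assay, with a stated time of 72 h (on this read-out higher numbers stand for weaker inhibition of growth and lower numbers for stronger inhibition of growth), compound 1 gives 2100 nM.
Compound 2 `COc1ccc(CNCCCNS(=O)(=O)c2cc(C(F)(F)F)cc(C(F)(F)F)c2)cc1OC` — compound 2 gives 3800 nM.
Compound 3 `CN(CCCNS(=O)(=O)c1cc(C(F)(F)F)cc(C(F)(F)F)c1)Cc1ccccc1` — compound 3 gives 28000 nM.

All three share the same core, a bis(trifluoromethyl)phenyl sulfonamide joined through a short saturated chain to an amine that carries a benzyl group. Among them compound 3 stands out with the highest number, so it is the weakest inhibitor of growth of the three; compound 2 is the closest to it, and compound 1 sits furthest away with the lowest number.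

Within the data shown here, only one step is known that touches the amine end of the chain: a 13-fold higher number from compound 1 to compound 3 (1.12 log units; beyond the scatter). In that step the amine lost its hydrogen and gained a methyl group, and the ring lost its bromine, and the number rose strongly.

Compound 4 `COc1cccc(CNCCCNS(=O)(=O)c2cc(C(F)(F)F)cc(C(F)(F)F)c2)c1` reverses part of that move: (3-methoxybenzyl)amino in place of benzyl(methyl)amino on a saturated chain carbon, three bonds along the chain from a sulfonamide nitrogen. The amine again carries a hydrogen, as it does in compound 1 and compound 2, and the ring again carries a substituent, a methoxy group. Because compound 1 gives 2100 nM and compound 2 gives 3800 nM with such amines, a large drop in number is expected for compound 4, roughly the reverse of the step from compound 1 to compound 3, that is an 8.0-fold lower number from compound 3 to compound 4 (0.90 log units; beyond the scatter) in this assay. Compound 4 is therefore estimated at 3500 nM, with a likely range from 1500 nM to 9000 nM.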

Compound 4, concentration for 50% growth inhibition: 1600 nM
Estimate against measurement, compound 4: 2.2-fold (0.34 log units) above; low and high end bracket the measured number.
By their numbers in this assay, from the lowest: compounds 4, 1 and 2 (each within the scatter of the next, the first and the last beyond it); then compound 3.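

In this assay, an 18-fold lower number from compound 3 to compound 4 (1.24 log units; beyond the scatter) shows that the amine end of the chain can move the number strongly, but this change both removes the methyl from the amine nitrogen and adds a methoxy group to the ring, so the step alone cannot separate the two. The ring itself can be read more cleanly: with hydrogen in place of methoxy on an aromatic carbon, there is a 2.4-fold lower number from compound 2 to compound 4 (0.38 log units; beyond the scatter), a modest step and far smaller than the amine change. With (3-methoxybenzyl)amino in place of ((4-bromobenzyl)amino)methyl, a 1.3-fold lower number from compound 1 to compound 4 (0.12 log units; within the scatter) stays within the scatter, so this substantial change in structure leaves no measurable difference in this assay.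

On these data alone, it remains open whether the methyl on the amine nitrogen or the missing methoxy group accounts for most of the large step, and how an amide in place of the amine, or a chlorine on the ring, would behave. Nothing available explains the cause of any of these steps.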